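Chlorophenyl isomer of compound 1: expected antiproliferative value

The source may report more compounds than this note shows. Statements on the series, on what has been measured and on what is new or still open speak of the compounds shown alone.

Measured so far in a functional assay on PC-9 cells (Homo sapiens) for antiproliferative activity, read by MTT assay; a higher number here means a weaker inhibitor, a lower number a stronger inhibitor:
compound 1 `C#CCSc1nc(Sc2nnnn2CCN(C)C)c(C#N)c(-c2ccc(Cl)cc2)n1`: 5300 nM
compound 2 `C#CCSc1nc(Sc2nccs2)c(C#N)c(-c2ccc(Cl)cc2)n1`: 4130 nM

These two numbers are the only measured points, and they cannot be told apart: a 1.3-fold lower number from compound 1 to compound 2 (0.11 log units; within the scatter). Within the data shown here, compound 1 therefore stands level with its one neighbour, with no wider range of values to place it in. Compound 3 `C#CCSc1nc(Sc2nnnn2CCN(C)C)c(C#N)c(-c2cccc(Cl)c2)n1` keeps the core of compound 1 and differs only in the aromatic group on the shared core: 3-chlorophenyl in place of 4-chlorophenyl on an aromatic carbon. Among the measured compounds shown here, the one measured step concerns the group on a sulfur, and no measured pair tests a chlorophenyl change, so its size offers only weak guidance. No step beyond the scatter is expected, in either direction, though the data cannot exclude one. The expected step is a 1.1-fold lower number from compound 1 to compound 3 (0.03 log units; within the scatter). For compound 3 the estimated value is 5000 nM, with an expected range of 2000 nM to 12000 nM.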

Compound 3, half-maximal inhibitory concentration: 6480 nM
Estimate against measurement, compound 3: 1.3-fold (0.11 log units) below, within the range that was stated.
By their numbers in this assay, from the lowest: compounds 2, 1 and 3 (each within the scatter of the next).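

In this assay, among these compounds, the first measured change at this position, on the aromatic carbon next to the ring nitrogen, gives a 1.2-fold higher number from compound 1 to compound 3 (0.09 log units; within the scatter). The 3-chlorophenyl and 4-chlorophenyl isomers therefore cannot be told apart in this pair, which carries the 1-(2-(dimethylamino)ethyl)-1H-tetrazol-5-yl group on the sulfur, so this change of chlorine position shows no measurable effect here. No measured information bears on a reason for this result.

Going by these compounds, it remains open whether the chlorine itself matters, which a plain phenyl, a methoxyphenyl or an aminophenyl group at this position would test. On these data alone, it is also open whether the two chlorophenyl isomers stay level when the sulfur carries 1,3-thiazol-2-yl instead.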